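The source may hold more compounds than are shown below. What is called first, only, known or untested is meant among the compounds shown, and "the series" means these compounds.

Measured compounds in a functional assay on A549 cells (Homo sapiens) for cytotoxicity, read by MTT assay, with a stated time of 24 h, tested at 20 uM; a lower number here means a stronger effect, a higher number a weaker effect of the compound at the concentration tested:

compound 1, `CCCCCCCCCCOC(=O)CCC(=O)N1CCN(CCCOc2cc3c(Nc4ccc(F)c(Cl)c4)ncnc3cc2OC)CC1`, gives 88.2%
compound 2, `CCCCCCCCCCCOC(=O)CCC(=O)N1CCN(CCCOc2cc3c(Nc4ccc(F)c(Cl)c4)ncnc3cc2OC)CC1`, gives 85.2%

Both numbers sit high, with much of the cell viability kept at the tested concentration. Compound 2 holds the smaller of the two, but the pair lies within the scatter of each other: the step of a number 3 percentage points lower from compound 1 to compound 2 (within the scatter). On the numbers shown, compound 2 is therefore not separated from compound 1, and no ordering between them can be read.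

Compound 3, `CCCCCCCCCCCCOC(=O)CCC(=O)N1CCN(CCCOc2cc3c(Nc4ccc(F)c(Cl)c4)ncnc3cc2OC)CC1`, is the next member. It differs from compound 2 by methyl in place of hydrogen on a saturated chain carbon, ten or more bonds along the chain from an oxygen next to a carbonyl group. Within the data shown here, the only measured step that bears on it is the one of the same kind, a number 3 percentage points lower from compound 1 to compound 2 (within the scatter), which stayed within the scatter. Two such steps in one direction may add up, so the expected step in this assay is a number 3.2 percentage points lower from compound 2 to compound 3 (within the scatter), pointing toward a slightly smaller read-out but not expected to clear the scatter. The estimated value for compound 3 in this assay is 82%, with a range from 70% to 93%.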

Compound 3, a percentage reported as activity, at one concentration (the size of the read-out at that concentration, not a potency): 86.8%
Beside the measured number, compound 3's estimate is 4.8 percentage points below it; measured number inside the range.
By their numbers in this assay, from the lowest: compounds 2, 3 and 1 (each within the scatter of the next).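

In this assay, the further methyl in place of hydrogen on a saturated chain carbon, ten or more bonds along the chain from an oxygen next to a carbonyl group, gives a number 1.6 percentage points higher from compound 2 to compound 3 (within the scatter) as its step, and ethyl in place of hydrogen at the same place gives a number 1.4 percentage points lower from compound 1 to compound 3 (within the scatter) as its step. The earlier pair offered one step of this kind, whereas three chain lengths now give a second methyl step and an ethyl step, and neither clears the scatter, so no trend with chain length can be read across compound 1, compound 2 and compound 3. No measurement is available that would explain these numbers.

Still open, on these data alone, is whether a longer chain at this place, or a chain ending in an amine or a carboxylic acid, would separate from these three compounds in this assay. Also open is how the series behaves when the ester oxygen is replaced by an amide nitrogen, since the three compounds shown all carry the same ester link and the same shared core.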